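Ethyl for chloro: notes on compound 3 to compound 4

This account rests on a few compounds, and the source may have more. Where it says the series, first, only, none or still open, it means among the compounds named here.

Measured so far:
compound 1 `CCCCN(CC)c1cc(C)nc2c1NC(=O)CN2c1ccc(C(C)C)cc1Br` 2.4 nM
compound 2 `CCCN(CCC)c1cc(C)nc2c1NC(=O)CN2c1ccc(C(C)C)cc1Br` 3.1 nM
compound 3 `CCCCN(CC)c1cc(C)nc2c1NC(=O)CN2c1ccc(Br)cc1Cl` 2.7 nM

In an assay on HEK-293T cells for displacement of a labelled ligand from corticotropin-releasing factor receptor 1 (Homo sapiens), read by scintillation counting, with a stated time of 2 h (a lower number here means a stronger inhibitor, a higher number a weaker inhibitor), compound 3 stands second highest of the three numbers, and its gaps to compound 1 and to compound 2 are both within the scatter. Compound 4 `CCCCN(CC)c1cc(C)nc2c1NC(=O)CN2c1ccc(Br)cc1CC` differs from compound 3 by ethyl in place of chloro on an aromatic carbon. Within the data shown here, no measured step touches this position; the one measured step, a 1.3-fold higher number from compound 1 to compound 2 (0.11 log units; within the scatter), changes the amino group instead and is within the scatter, and the differing aryl groups of compound 1 and compound 3 give numbers within the scatter of each other. For compound 4 the expected step of a 1.1-fold higher number from compound 3 to compound 4 (0.05 log units; within the scatter) is therefore none beyond the scatter. Compound 4 is estimated at 3 nM in this assay, within 1 nM to 9 nM.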

Compound 4, inhibition constant: 2.5 nM
For compound 4 the middle estimate is 1.2-fold (0.08 log units) above the measured one; measured number inside the range.
By their numbers in this assay, from the lowest: compounds 1, 4, 3 and 2 (each within the scatter of the next).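

In this assay, among these compounds, the change from 4-bromo-2-chlorophenyl to 4-bromo-2-ethylphenyl gives a 1.1-fold lower number from compound 3 to compound 4 (0.03 log units; within the scatter), the only measured step at this position, ortho to a large group. Ethyl, with 2 heavy atoms, and chloro, with 1 heavy atom, therefore give numbers within the scatter of each other here. No evidence at hand accounts for this result.

Open, as far as these compounds go, is whether a longer chain such as propyl, or a methoxy group or an amine, would also stay within the scatter at this position. The compounds shown compare only chloro and ethyl here.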